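Swapping 4-bromophenyl for 2,4-dichlorophenyl: expected cell tolerance

A few compounds are considered here, and "the series" means these few. Any claim that something is new, unique, unknown or untested is made for them only; others in the source may bear on it.

Three measured compounds share one core and differ only in the group on the carbonyl carbon. Compound 1 `O=C(Nc1ncc(Cc2ccc(F)cc2)s1)C1CCCCC1` carries a cyclohexyl there, compound 2 `O=C(Nc1ncc(Cc2ccc(F)cc2)s1)c1ccccc1` a plain phenyl, and compound 3 `O=C(Nc1ncc(Cc2ccc(F)cc2)s1)c1ccc(Br)cc1` a 4-bromophenyl. In an ADME assay on HepG2 2.2.15 cells (Homo sapiens) for cytotoxicity (a higher number here means that more compound is tolerated, a lower number that less compound is tolerated), compound 1 gives > 50000 nM, which is a limit of the assay and not a number. Compound 2 is reported in this assay as "not toxic" (no number reported), with no number. Compound 3 also reaches a limit in this assay, at > 50000 nM. Compound 3 thus stands where two of the three results sit, namely at the limit of > 50000 nM in this assay, at which 2 of the 3 values shown sit. Among the measured compounds shown here, the only step joining two measured compounds is a step that the two limits leave unreadable from compound 1 to compound 3; both of its ends are limits, so its size cannot be read.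

Compound 4 `O=C(Nc1ncc(Cc2ccc(F)cc2)s1)c1ccc(Cl)cc1Cl` differs from compound 3 by 2,4-dichlorophenyl in place of 4-bromophenyl on a carbonyl carbon. No readable measured step bears on this change. With every numbered result here a limit, compound 4 is expected to give 50000 nM in this assay, within 25000 nM to 200000 nM. The expected step of a number no higher from compound 3 to compound 4 (the limit leaves the size open) is estimated to be none beyond the scatter.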

Compound 4, half-maximal cytotoxic concentration: > 50000 nM
Compound 4: only a limit was reported (the forecaster's own chance of this, stated with the estimate: 85%); the middle value lies on the limit itself.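

Among the compounds shown here, compound 4 gives only a limit, as do compound 1 and compound 3, and no step from either of them to compound 4 can be read. The results gather at one point: the limit of > 50000 nM in this assay, at which 3 of the 4 values shown sit.

What the compounds shown leave open is how much of each the cells tolerate, and whether the group on the carbonyl carbon alters that.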